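Isopropyl for benzyl on the sulfur: an expected outcome

The source may report more compounds than this note shows. Statements on the series, on what has been measured and on what is new or still open speak of the compounds shown alone.

Compound 1, `O=c1c2ccccc2[se]n1-c1nc(SCc2ccccc2)n[nH]1`: > 50000 nM
Compound 2, `CC(C)CSc1n[nH]c(-n2[se]c3ccccc3c2=O)n1`: 34900 nM
Compound 3, `Cc1ccc(CSc2n[nH]c(-n3[se]c4ccccc4c3=O)n2)cc1`: 34800 nM

Three compounds sharing the core of compound 1 were tested in a functional assay on HeLa cells (Homo sapiens) for antiproliferative activity, read by CCK-8 assay, with a stated time of 48 h; a lower number here means a stronger inhibitor, a higher number a weaker inhibitor. Compound 1 sits at the limit of > 50000 nM in this assay, at which 1 of the 3 values shown sits, so its value is a limit and not a number. Compound 2 and compound 3 both give numbers, and they sit within the scatter of each other, with a 1.0-fold lower number from compound 2 to compound 3 (0.00 log units; within the scatter).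

Compound 4, `CC(C)Sc1n[nH]c(-n2[se]c3ccccc3c2=O)n1`, has not been measured. It differs from compound 1 in one place: isopropyl in place of benzyl on a sulfur. The closest measured step is an at least 1.4-fold lower number from compound 1 to compound 2 (0.15 log units; that floor lies within the scatter), and the other change at the same end of the molecule gave an at least 1.4-fold lower number from compound 1 to compound 3 (0.15 log units; that floor lies within the scatter). Both steps start from the limit of compound 1 and only reach a floor that lies within the scatter. Compound 4 is therefore expected to show at most a small lowering in this assay, and a limit remains possible. Compound 4 is estimated at 40000 nM, within a range from 20000 nM to 80000 nM. The expected step would be an at least 1.2-fold lower number from compound 1 to compound 4 (0.09 log units; that floor lies within the scatter).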

Compound 4, half-maximal inhibitory concentration: 34600 nM
Compound 4: the middle estimate sits 1.2-fold (0.06 log units) above what was measured; low and high end bracket the measured number.
By their numbers in this assay, from the lowest: compounds 4, 3 and 2 (each within the scatter of the next). At a limit, above all of these: compound 1.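

In this assay, isopropyl on the sulfur cannot be told apart from isobutyl, with a 1.0-fold lower number from compound 2 to compound 4 (0.00 log units; within the scatter), or from 4-methylbenzyl, with a 1.0-fold lower number from compound 3 to compound 4 (0.00 log units; within the scatter). Compound 1, which carries benzyl, is the only one of the four that stays at a limit and not a number: the limit of > 50000 nM in this assay, at which 1 of the 4 values shown sits. Isopropyl in place of benzyl gives an at least 1.4-fold lower number from compound 1 to compound 4 (0.15 log units; that floor lies within the scatter), so even this exchange of a ring-bearing group for one without a ring cannot be shown to matter here.

As far as these compounds go, what stays open is whether any group on this sulfur can give a number clearly apart from these. A longer chain ending in an amine or a carboxylic acid would be one such test, and the compounds shown say nothing about how it would read.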